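Ring-fused amine in place of the aminoalkyl chain

The source may hold more compounds than are shown below. What is called first, only, known or untested is meant among the compounds shown, and "the series" means these compounds.

Measured compounds:
- compound 1, `CNCCCCNc1cc2c(cc1F)c(=O)c(C(=O)O)cn2Cc1ccc(-c2ccccc2)cc1`, in an assay on isolated protein for inhibition of DNA topoisomerase 1 (Homo sapiens), with a stated time of 15 min (on this read-out higher numbers stand for weaker inhibition and lower numbers for stronger inhibition), gives 88300 nM
- compound 2, `CNCCNc1c(F)cc2c(=O)c(C(=O)O)cn(Cc3ccc(-c4ccccc4)cc3)c2c1OC`, in this assay gives only a limit, > 200000 nM
- compound 3, `CNCCCCNc1c(F)cc2c(=O)c(C(=O)O)cn(Cc3ccc(-c4ccccc4)cc3)c2c1OC`, in this assay gives only a limit, > 200000 nM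

Compound 1 holds the only number shown; the other two values sit at the limit of > 200000 nM in this assay, at which 2 of the 3 values shown sit. Compound 4, `O=C(O)c1cn(Cc2ccc(-c3ccccc3)cc2)c2cc(N3C[C@H]4CCNC[C@H]4C3)c(F)cc2c1=O`, is not yet measured. It differs from compound 1 by a group of 9 heavy atoms (7 carbon, 2 nitrogen; one five-membered non-aromatic ring with 1 hetero atom, one six-membered non-aromatic ring with 1 hetero atom) in place of a group of 7 heavy atoms (5 carbon, 2 nitrogen; no ring), on an aromatic carbon. Neither measured step touches this part: an at least 2.2-fold higher number from compound 1 to compound 3 (0.35 log units; beyond the scatter) concerns the methoxy group, and a step that the two limits leave unreadable from compound 2 to compound 3 concerns the chain length. Going by the values given here, no step therefore bears on the change from compound 1 to compound 4, and the direction is open. Compound 4 is expected to lie near compound 1, with the shift a 1.5-fold lower number from compound 1 to compound 4 (0.17 log units; within the scatter) kept within a wide band. The estimate for compound 4 in this assay is 60000 nM, from 10000 nM to 200000 nM.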

Compound 4, half-maximal inhibitory concentration: 61000 nM
Compound 4: middle estimate off by 1.0-fold (0.01 log units), on the low side; low and high end bracket the measured number.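

In this assay the ring-fused amine stands in place of the (4-(methylamino)butyl)amino chain with a 1.4-fold lower number from compound 1 to compound 4 (0.16 log units; within the scatter) and no readable shift. On the core of compound 1, this aromatic carbon ortho to the fluoro group therefore accepts a ring-fused amine with 2 defined stereocentres as well as an open chain, without any gain in inhibition. Readable room remains limited in this small set: the limit of > 200000 nM in this assay, at which 2 of the 4 values shown sit. Going by these compounds, whether a piperazine or a pyrrolidine at this carbon would shift the number beyond the scatter remains open. Also open, on these data alone, are the opposite stereoisomer of the ring-fused amine and the effect of a methoxy group on compound 4.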